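One Ring Exchanged: From Compound 2 to Compound 3

The source may hold more compounds than are shown below. What is called first, only, known or untested is meant among the compounds shown, and "the series" means these compounds.

Measured compounds:
compound 1 `CCO/C(O)=C1\C(C)=NC(COCCNc2n[nH]c(N)n2)=C(C(=O)OC)C1c1cccc(Cl)c1Cl`: 100 nM
compound 2 `CCO/C(O)=C1\C(COCCNc2nc(O)cs2)=NC(C)=C(C(=O)OC)C1c1cccc(Cl)c1Cl`: 20 nM

In a functional assay (aorta) with Rattus norvegicus as the target (on this read-out lower numbers stand for stronger inhibition and higher numbers for weaker inhibition), compound 2 gives 20 nM, the lowest number of the two; compound 1 gives 100 nM, a higher number beyond the scatter. Compound 3 `CCO/C(O)=C1\C(COCCNc2nccnc2NC)=NC(C)=C(C(=O)OC)C1c1cccc(Cl)c1Cl` keeps the shared core of compound 2 and differs only in the terminal group: 3-(methylamino)pyrazin-2-yl in place of 4-hydroxy-1,3-thiazol-2-yl on an amine nitrogen. Among the compounds with values here, no measured pair shows this kind of exchange, so the expected step is uncertain; a small rise in number, around the edge of the scatter, is expected, namely a 2.0-fold higher number from compound 2 to compound 3 (0.30 log units; within the scatter). Compound 3 is therefore estimated at 40 nM, within 10 nM to 160 nM.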

Compound 3, half-maximal inhibitory concentration: 5.01 nM
Beside the measured number, compound 3's estimate is 8.0-fold (0.90 log units) above it; measured number below the stated range.
By their numbers in this assay, from the lowest: compound 3; then compound 2; then compound 1.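

In this assay, the terminal group on the amine nitrogen clearly affects the read-out: 3-(methylamino)pyrazin-2-yl in place of 4-hydroxy-1,3-thiazol-2-yl gives a 4.0-fold lower number from compound 2 to compound 3 (0.60 log units; beyond the scatter) with the shared core unchanged. This position therefore accepts a six-membered aromatic ring as well as a five-membered one, and the lower number lies beyond the scatter. Nothing measured here explains the difference.

Still open, on these data alone, is whether the methylamino group or the ring carries the change. An unsubstituted pyrazin-2-yl group, or a dimethylamino or methoxy group in place of methylamino, would help separate the two.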